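Ester variation at the carbonyl of the shared core

The source may report more compounds than this note shows. Statements on the series, on what has been measured and on what is new or still open speak of the compounds shown alone.

Compound 1 `CCn1c(C(=O)NCCCN(C)C)ccc1C(CC)(CC)c1ccc(OCC(=O)C(C)(C)C)c(C)c1` gives 96 nM in an assay on HL-60 cells for agonist activity at vitamin D3 receptor (Homo sapiens), read by microscopy, with a stated time of 96 h; on this read-out lower numbers stand for an effect already at smaller amounts and higher numbers for an effect only at larger amounts of compound. Among the compounds with values here, compound 2 `C#CCNC(=O)c1ccc(C(CC)(CC)c2ccc(OCC(=O)C(C)(C)C)c(C)c2)n1CC` gives 2200 nM, and compound 3 `CCn1c(C(=O)OC(C)CCO)ccc1C(CC)(CC)c1ccc(OCC(=O)C(C)(C)C)c(C)c1` gives 380 nM, which places compound 3 second highest of the three numbers measured so far. The step from compound 3 to compound 4 `CCOC(=O)c1ccc(OC(=O)c2ccc(C(CC)(CC)c3ccc(OCC(=O)C(C)(C)C)c(C)c3)n2CC)cc1` is 4-(ethoxycarbonyl)phenyl in place of 3-hydroxy-1-methylpropyl on an oxygen next to a carbonyl group. Within the data shown here, the steps that bear on it are those made on the carbonyl carbon: a 4.0-fold higher number from compound 1 to compound 3 (0.60 log units; beyond the scatter) and a 5.8-fold lower number from compound 2 to compound 3 (0.76 log units; beyond the scatter), both modest, alongside a 23-fold higher number from compound 1 to compound 2 (1.36 log units; beyond the scatter), which was large. Changes at this position have moved the number in both directions, so the present replacement is expected to give a step of a 1.3-fold higher number from compound 3 to compound 4 (0.12 log units; within the scatter), within or only just beyond the scatter. Compound 4 is therefore estimated at 500 nM, with a range of 120 nM to 2000 nM.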

Compound 4, half-maximal effective concentration: 45600 nM
The estimate for compound 4 lay 91-fold (1.96 log units) below the measured number, outside the stated range (above it).
By their numbers in this assay, from the lowest: compound 1; then compound 3; then compound 2; then compound 4.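

Within the data shown here, at the oxygen next to a carbonyl group, 4-(ethoxycarbonyl)phenyl in place of 3-hydroxy-1-methylpropyl gives a 120-fold higher number from compound 3 to compound 4 (2.08 log units; beyond the scatter) in this assay and is a larger step than any among the earlier compounds. The comparisons with the two amides are also large, with a 21-fold higher number from compound 2 to compound 4 (1.32 log units; beyond the scatter) and a 480-fold higher number from compound 1 to compound 4 (2.68 log units; beyond the scatter) on the carbonyl carbon, so numbers at this position span a far wider spread than the first three compounds showed. No measurement available here accounts for the size of these steps.

Open, on these data alone, is whether the loss follows the aromatic ring or its ethoxycarbonyl group. A plain phenyl group or a carboxylic acid in that ring's substituent place would separate the two.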